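The source may report more compounds than this note shows. Statements on the series, on what has been measured and on what is new or still open speak of the compounds shown alone.

Compound 1 `COc1ccc(C)cc1N1C(=O)CSC1c1cccc(C(=O)NCCCCc2ccccc2)c1`: 300 nM
Compound 2 `O=C(NCCCCc1ccccc1)c1cccc(C2SCC(=O)N2c2cnccn2)c1`: > 1000 nM, a limit
Compound 3 `CCN1C(=O)CSC1c1cccc(C(=O)NCCCCc2ccccc2)c1`: > 1000 nM, a limit

In a functional assay on HOS-TE85 cells (Homo sapiens) for inhibition, read by CCK-8 assay, with a stated time of 72 h (on this read-out lower numbers stand for stronger inhibition and higher numbers for weaker inhibition), compound 3 stands at > 1000 nM, which is a limit and not a number. This is the limit of > 1000 nM in this assay, at which 2 of the 3 values shown sit. Compound 4 `COc1cc(F)ccc1N1C(=O)CSC1c1cccc(C(=O)NCCCCc2ccccc2)c1` brings the change 4-fluoro-2-methoxyphenyl in place of ethyl on an amide-type nitrogen in a ring. For the measured compounds named here, two measured steps bear on this. One is an at least 3.3-fold higher number from compound 1 to compound 3 (0.52 log units; beyond the scatter), with ethyl in place of 2-methoxy-5-methylphenyl, the reverse kind of swap. The other is an at least 3.3-fold higher number from compound 1 to compound 2 (0.52 log units; beyond the scatter), with pyrazin-2-yl in that place. Only compound 1, which also carries a substituted phenyl there, gives a number, so compound 4 is expected to resemble it. A lower number is therefore expected, an at least 2.5-fold lower number from compound 3 to compound 4 (0.39 log units; beyond the scatter). For compound 4 the estimate is 400 nM, with an expected range of 150 nM to 1000 nM.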

Compound 4, half-maximal inhibitory concentration: 71.1 nM
Beside the measured number, compound 4's estimate is 5.6-fold (0.75 log units) above it, and the stated range ends above it.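

On the ring nitrogen, 4-fluoro-2-methoxyphenyl in place of ethyl gives an at least 14-fold lower number from compound 3 to compound 4 (1.14 log units; beyond the scatter), and in place of pyrazin-2-yl it gives an at least 14-fold lower number from compound 2 to compound 4 (1.14 log units; beyond the scatter). Both steps are open-ended, since compound 2 and compound 3 each stand at a limit and not a number: the limit of > 1000 nM in this assay, at which 2 of the 4 values shown sit.

The substituents on the phenyl ring also count, not only its presence, as 4-fluoro-2-methoxyphenyl in place of 2-methoxy-5-methylphenyl gives a 4.2-fold lower number from compound 1 to compound 4 (0.63 log units; beyond the scatter).

Compound 1 and compound 4 differ in both the fluoro and the methyl group, so which of them accounts for this step stays open. From the compounds shown here alone, whether an amine or a carboxylic acid on the phenyl ring would be tolerated also remains unknown.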